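Dichlorophenyl analogue of compound 1: antiproliferative expectation

The source may hold more compounds than are shown below. What is called first, only, known or untested is meant among the compounds shown, and "the series" means these compounds.

The series rests on three measured compounds. Compound 1 `COc1ccc(-c2nc(SCC(=O)c3sc(-c4ccccc4)nc3C)[nH]c(=O)c2C#N)cc1` is tested in a functional assay on U-87MG ATCC cells for antiproliferative activity against U-87 MG (Homo sapiens), read by MTT assay, with a stated time of 48 h, tested at 50 uM (on this read-out higher numbers stand for a weaker effect at the one concentration tested and lower numbers for a stronger effect), and gives 52.1%. Compound 3 `Cc1nc(-c2ccc(Cl)cc2)sc1C(=O)CSc1nc(-c2ccc(Cl)cc2)c(C#N)c(=O)[nH]1` gives 60% in this assay, and compound 2 `COc1ccc(-c2nc(C)c(C(=O)CSc3nc(N)c(C#N)c(-c4ccc(OC)cc4)n3)s2)cc1` gives 13% in this assay. Among these three numbers compound 1 stands second highest: its nearest neighbour is compound 3, which lies within the usual scatter of it, while compound 2 lies well beyond the scatter and shows the stronger effect of the set. Among the measured compounds shown here, no pair of measured compounds differs in a single place, so no measured step is available to calibrate the change below.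

Compound 4 `Cc1nc(-c2ccccc2)sc1C(=O)CSc1nc(-c2ccc(Cl)c(Cl)c2)c(C#N)c(=O)[nH]1` is not yet measured. Relative to compound 1 the change is 3,4-dichlorophenyl in place of 4-methoxyphenyl on an aromatic carbon. For the measured compounds named here, the only measured compound bearing chlorine on that ring, compound 3, shows a number within the scatter of compound 1, which gives no reason to expect a shift in either direction beyond the scatter. The step from compound 1 to compound 4 is therefore expected to be small, a number 2.9 percentage points higher from compound 1 to compound 4 (within the scatter), with the direction uncertain. On that basis compound 4 is estimated at 55% in this assay, within a range from 35% to 75%.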

Compound 4, a percentage reported as activity, at one concentration (the size of the read-out at that concentration, not a potency): 75.3%
The estimate for compound 4 lay 20.3 percentage points below the measured number; measured number above the stated range.
By their numbers in this assay, from the lowest: compound 2; then compounds 1 and 3 (each within the scatter of the next); then compound 4.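

In this assay the exchange of 4-methoxyphenyl for 3,4-dichlorophenyl gives a number 23.2 percentage points higher from compound 1 to compound 4 (beyond the scatter) and so a weaker effect at the one concentration tested. Among the compounds shown here, this is the first single-place comparison, and it shows that the aromatic carbon ortho to a cyano group is not indifferent to this exchange, with the dichlorinated ring on the weaker side. No measurement at hand bears on why the number moves.

For the compounds shown here, the one step changes both the group that leaves and the group that enters, so it remains open whether the shift follows the loss of the methoxy group or the arrival of the two chlorine atoms, and how a 4-aminophenyl or a 4-hydroxyphenyl would read on the same carbon. Going by these compounds alone, it also remains open whether the step would keep its direction and size with other groups elsewhere on the shared core, as this is the only pair that differs in one place.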